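From isobutylamino to piperidin-1-yl on a carbonyl carbon

The source may hold more compounds than are shown below. What is called first, only, known or untested is meant among the compounds shown, and "the series" means these compounds.

Of the compounds shown here, two have been measured in a functional assay on SK-N-SH cells (Homo sapiens) for inhibition, read by trypan blue exclusion, with a stated time of 48 h; a lower number here means a stronger inhibitor, a higher number a weaker inhibitor. Compound 1 `CCCCCCC[C@@H](C/C=C/CCC(=O)N1CCCCC1)OC` gives > 100000 nM, which is a limit of the assay and not a number. Compound 2 `CCCCCCC[C@H](O)C/C=C/CCC(=O)NCC(C)C` gives > 100000 nM, which is also a limit. Compound 2 therefore has no exact potency on record and stands at the limit of > 100000 nM in this assay, at which 2 of the 2 values shown sit.

Compound 3 `CCCCCCC[C@H](O)C/C=C/CCC(=O)N1CCCCC1` differs from compound 2 in one place, with piperidin-1-yl in place of isobutylamino on a carbonyl carbon. Going by the values given here, no measured pair shows what this change does. With the limit of compound 2 at > 100000 nM, no shift beyond the usual scatter is expected in this assay, in either direction. The estimated step of a number no higher from compound 2 to compound 3 (the limit leaves the size open) is therefore expected to be small. For compound 3, the expected value is 100000 nM, with an estimated range from 30000 nM to 200000 nM.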

Compound 3, half-maximal inhibitory concentration: 100000 nM
Beside the measured number, compound 3's estimate shows no gap at the digits printed; the range from low to high includes it.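

In this assay, going by these compounds alone, compound 3 gives 100000 nM, the only value shown that is an exact number, so this series now has a measured reference point, with a number no higher from compound 2 to compound 3 (the limit leaves the size open) for piperidin-1-yl in place of isobutylamino on a carbonyl carbon and a number no higher from compound 1 to compound 3 (the limit leaves the size open) for hydrogen in place of methyl on an oxygen on a saturated carbon. Neither swapping isobutylamino for piperidin-1-yl on the carbonyl carbon nor swapping methyl for hydrogen on the oxygen can be given a size, as the steps to compound 3 from compound 1 and compound 2 cannot be read and no order among the three can be stated. All three compounds therefore remain weak or unresolved at the top of the tested range: the limit of > 100000 nM in this assay, at which 2 of the 3 values shown sit.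

Still open, going by these compounds, is whether another group on the carbonyl carbon, such as morpholin-4-yl or a simple amine, would give a clearly lower number. A longer chain on the shared core is equally untested in the compounds shown.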